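A Hydroxy Group on a Weakly Active Chain

This account rests on a few compounds, and the source may have more. Where it says the series, first, only, none or still open, it means among the compounds named here.

Two related compounds have so far been tested in a functional assay on HOS cells (Homo sapiens) for antiproliferative activity, read by sulforhodamine B assay; on this read-out higher numbers stand for weaker inhibition of growth and lower numbers for stronger inhibition of growth. Among the compounds with values here, compound 1 `CCCC[C@@H]1O[C@H](COCc2ccccc2)[C@@H](OCc2ccccc2)[C@H](OCc2ccccc2)[C@H]1O` gives 40100 nM, the only true number available, and it reflects weak inhibition of growth. Compound 2 `CC(=O)O[C@@H]1[C@@H](OCc2ccccc2)[C@H](OCc2ccccc2)[C@@H](COCc2ccccc2)O[C@@H]1CC(C)C` gives > 50000 nM, which is a limit of the assay and not a number.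

Compound 3 `OCCC[C@@H]1O[C@H](COCc2ccccc2)[C@@H](OCc2ccccc2)[C@H](OCc2ccccc2)[C@H]1O` differs from compound 1 in a single place: hydroxy in place of methyl on a saturated chain carbon, three bonds along the chain from a saturated ring carbon. This is hydroxy in place of methyl on a saturated chain carbon, three bonds along the chain from a saturated ring carbon, so butyl becomes 3-hydroxypropyl. Within the data shown here, no measured pair shows what such a change does, so only a small move with no firm direction is expected, perhaps nothing beyond the scatter. The expected size is a 1.1-fold lower number from compound 1 to compound 3 (0.06 log units; within the scatter). For compound 3 the estimated value is 35000 nM, with an expected range of 14000 nM to 50000 nM.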

Compound 3, concentration for 50% growth inhibition: > 50000 nM
Compound 3 ended at the assay's limit (the forecaster's own chance of this, stated with the estimate: 40%); middle value at least 1.4-fold (0.15 log units) from the limit.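

In this assay compound 3 gives > 50000 nM, which is a limit of the assay and not a number. Within the data shown here, this is the first measured pair for this position: going from butyl to 3-hydroxypropyl gives an at least 1.2-fold higher number from compound 1 to compound 3 (0.09 log units; that floor lies within the scatter), so the change brought no visible gain in growth inhibition, although the floor of that step lies within the scatter. The true size of the step cannot be read, because the values crowd at the top of the measurable range: the limit of > 50000 nM in this assay, at which 2 of the 3 values shown sit.

Still open, on these data alone, is whether a different group at the chain end, such as an amine or a carboxylic acid, or a longer chain, would bring the number down into the measurable range. The only true number shown belongs to compound 1, so no change at this position has been seen to strengthen inhibition of growth.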